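The source may report more compounds than this note shows. Statements on the series, on what has been measured and on what is new or still open speak of the compounds shown alone.

Of the compounds shown here, three share one core and have been tested in a functional assay on A549 cells (Homo sapiens) for antiproliferative activity, read by MTT assay, with a stated time of 48 h; a higher number here means a weaker inhibitor of growth, a lower number a stronger inhibitor of growth. Compound 1, with structure `COC(=O)N1N=C(c2ccccc2)CC1c1cc(OC)c(OC)c(OC)c1`, gives 2880 nM and stands second highest of the three numbers; compound 2, `COC(=O)N1N=C(c2cccc(OC)c2)CC1c1cc(OC)c(OC)c(OC)c1`, gives 2590 nM, and compound 3, `COC(=O)N1N=C(c2cccc(O)c2)CC1c1cc(OC)c(OC)c(OC)c1`, gives 3170 nM. The step of a 1.1-fold lower number from compound 1 to compound 2 (0.05 log units; within the scatter) and the step of a 1.1-fold higher number from compound 1 to compound 3 (0.04 log units; within the scatter) both lie within the scatter, as does a 1.2-fold higher number from compound 2 to compound 3 (0.09 log units; within the scatter), so the three compounds are indistinguishable here.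

Compound 4, `COC(=O)N1N=C(c2ccccc2)CC1c1ccc(OC)c(OC)c1`, is not yet measured. It differs from compound 1 by hydrogen in place of methoxy on an aromatic carbon. Within the data shown here, all three measured steps change the phenyl ring at the other end of the core, none touches the ring that is altered in compound 4, so there is no measured step to lean on for this change. The expectation therefore rests only on compound 1 itself and its value 2880 nM, with the removed methoxy group as an untested change whose effect could be in either direction.

Compound 4 is estimated to give 6000 nM in this assay, within a broad range from 2000 nM to 20000 nM. This expected step, a 2.1-fold higher number from compound 1 to compound 4 (0.32 log units; beyond the scatter), leans toward a weaker inhibitor but with little confidence.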

Compound 4, concentration for 50% growth inhibition: 7320 nM
Compound 4: middle estimate off by 1.2-fold (0.09 log units), on the low side, within the range that was stated.
By their numbers in this assay, from the lowest: compounds 2, 1 and 3 (each within the scatter of the next); then compound 4.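

In this assay, hydrogen in place of methoxy on this aromatic carbon, ortho to a methoxy group and meta to a second one, gives a 2.5-fold higher number from compound 1 to compound 4 (0.41 log units; beyond the scatter). This is the first step here that lies beyond the scatter: the changes on the phenyl ring at the other end of the core all stayed within it, so growth inhibition among these compounds responds to this methoxy group, if only modestly, and not to those changes. Nothing measured here bears on why the loss of this group weakens the compound.

One step on this ring cannot tell whether the methoxy group itself matters or whether any group on this carbon would do as well, and an ethoxy group, a chlorine atom or an amine in the same place would help to separate those two readings. The compounds shown also leave open whether removing either of the other methoxy groups on this ring would have a similar effect, or whether this position is a special case.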